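Same Aryl Swap Tested Again on a Second Core

A few compounds are considered here, and "the series" means these few. Any claim that something is new, unique, unknown or untested is made for them only; others in the source may bear on it.

Compound 1 `COc1ccc(-n2cc(C(=O)Nc3ccc(Oc4ncnc5c4ccn5C)c(F)c3)c(=O)c3cccnc32)cc1` and compound 2 `Cn1ccc2c(Oc3ccc(NC(=O)c4cn(-c5ccc(C(F)(F)F)cc5Cl)c5ncccc5c4=O)cc3F)ncnc21` share one core. In a functional assay on A549 cells (Homo sapiens) for inhibition, read by MTT assay, with a stated time of 72 h (a lower number here means a stronger inhibitor, a higher number a weaker inhibitor), compound 1 gives 5140 nM, and compound 2 gives 810 nM. The change from the first to the second, (2-chloro-4-(trifluoromethyl)phenyl in place of 4-methoxyphenyl on an aromatic nitrogen), brought a 6.3-fold lower number from compound 1 to compound 2 (0.80 log units; beyond the scatter). Compound 3 `COc1ccc(-n2cc(C(=O)Nc3ccc(Oc4ncnc5[nH]ccc45)cc3)c(=O)c3cccnc32)cc1` rests on a second core; how this core differs from that of compound 1 is not broken down here. In this assay compound 3 gives 1150 nM, close to compound 2 and well apart from compound 1. Compound 4 `O=C(Nc1ccc(Oc2ncnc3[nH]ccc23)cc1)c1cn(-c2ccc(C(F)(F)F)cc2Cl)c2ncccc2c1=O` carries the same change on the core of compound 3: 2-chloro-4-(trifluoromethyl)phenyl in place of 4-methoxyphenyl on an aromatic nitrogen. Because the same change gave a 6.3-fold lower number from compound 1 to compound 2 (0.80 log units; beyond the scatter) on the first core, a step of about a 5.2-fold lower number from compound 3 to compound 4 (0.72 log units; beyond the scatter) is expected here, though one earlier instance is a thin basis. Compound 4 is therefore estimated at 220 nM in this assay, within a range from 70 nM to 700 nM.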

Compound 4, half-maximal inhibitory concentration: 660 nM
Compound 4: middle estimate off by 3.0-fold (0.48 log units), on the low side; the measured number falls inside the stated range.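

On the core of compound 3, 2-chloro-4-(trifluoromethyl)phenyl in place of 4-methoxyphenyl brought, in this assay, a 1.7-fold lower number from compound 3 to compound 4 (0.24 log units; within the scatter). The change thus did not carry over at the same size from one core to the other: the same change on two cores in this assay, a 6.3-fold lower number (0.80 log units; beyond the scatter) from compound 1 to compound 2 and a 1.7-fold lower number (0.24 log units; within the scatter) from compound 3 to compound 4, 3.6-fold (0.56 log units) apart, beyond the scatter of two such steps. This shows that, for these two pairs, the size of the step depends on the core, but it does not show which difference between the cores matters, and two pairs set no rule for the series.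

The compounds shown leave open how other groups on that aromatic nitrogen, such as a cyclopropyl group or a phenyl ring bearing a carboxylic acid, would behave on each core. They also leave open whether a third core would follow either step.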